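The source may report more compounds than this note shows. Statements on the series, on what has been measured and on what is new or still open speak of the compounds shown alone.

Working notes on the series. All three measured compounds share one core and differ only in the two aryloxy groups. Compound 1 `CC(C)CC1(O)CCN(C(=O)Nc2cc(Oc3ccc(C(=O)O)cc3)cc(Oc3ccc(F)cc3F)c2)CC1` gives 20 nM in a functional assay on CHO cells for antagonist activity at sphingosine 1-phosphate receptor 2 (Homo sapiens), read by fluorescence; on this read-out higher numbers stand for weaker inhibition and lower numbers for stronger inhibition. Compound 2 `CC(C)CC1(O)CCN(C(=O)Nc2cc(Oc3ccc(F)cc3)cc(Oc3ccc(CC(=O)O)cc3)c2)CC1` gives 21 nM in this assay. Compound 3 `CC(C)CC1(O)CCN(C(=O)Nc2cc(Oc3ccc(C(=O)O)cc3)cc(Oc3ccc(F)c(F)c3)c2)CC1` gives 25 nM in this assay, the highest number of the three, yet within the scatter of both compound 1 and compound 2, so no ranking among them can be read from these numbers. For the measured compounds named here, the single one-point step measured so far, a 1.3-fold higher number from compound 1 to compound 3 (0.10 log units; within the scatter), rearranged the fluorines on the fluorinated ring and stayed within the scatter.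

Compound 4 `CC(C)CC1(O)CCN(C(=O)Nc2cc(Oc3ccc(F)cc3)cc(Oc3ccc(C(=O)O)cc3)c2)CC1` differs from compound 3 by hydrogen in place of fluoro on an aromatic carbon. Going by the values given here, no measured step removes a fluorine from this ring, so the only guidance is indirect: the fluorine rearrangement a 1.3-fold higher number from compound 1 to compound 3 (0.10 log units; within the scatter) did not move the number beyond the scatter, and compound 2, which also carries a 4-fluorophenyl group, sits within the scatter of compound 3. The expected step of no change at the digits printed from compound 3 to compound 4 (within the scatter) is therefore no change beyond the scatter. Compound 4 is estimated at 25 nM, with a range from 10 nM to 60 nM.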

Compound 4, half-maximal inhibitory concentration: 4 nM
Compound 4: middle estimate off by 6.3-fold (0.80 log units), on the high side; measured number outside the range, below it.
By their numbers in this assay, from the lowest: compound 4; then compounds 1, 2 and 3 (each within the scatter of the next).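

Taking one fluorine off the fluorinated ring matters here, whichever difluorophenyl group it starts from: a 6.3-fold lower number from compound 3 to compound 4 (0.80 log units; beyond the scatter) and a 5.0-fold lower number from compound 1 to compound 4 (0.70 log units; beyond the scatter) both lie beyond the scatter, whereas the earlier rearrangement of the fluorines did not. The other aryloxy group also responds, with carboxy in place of carboxymethyl giving a 5.3-fold lower number from compound 2 to compound 4 (0.72 log units; beyond the scatter) while the 4-fluorophenoxy group stays the same. Nothing shown bears on what lies behind either step.

The compounds shown leave open whether the remaining fluoro is needed at all, or whether hydrogen or chloro in its place would keep the number of compound 4. They also leave open how far the acid side tolerates change, for instance a tetrazole in place of the carboxy group.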